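Exchanging carboxy for chloro on an aromatic ring

This account rests on a few compounds, and the source may have more. Where it says the series, first, only, none or still open, it means among the compounds named here.

Measured in a functional assay on DU-145 cells (Homo sapiens) for inhibition, read by trypan blue exclusion, with a stated time of 96 h; a higher number here means a weaker inhibitor of growth, a lower number a stronger inhibitor of growth:
Compound 1 `Cc1ccsc1/C=C(/SCc1ccc(Cl)cc1)C(=O)c1ccc(Cl)cc1`: 50000 nM
Compound 2 `O=C(/C(=C\c1ccc(Br)cc1)SCc1ccc(Cl)cc1)c1ccc(Cl)cc1`: 1000 nM
Compound 3 `CSc1ccc(/C=C(/SCc2ccc(Cl)cc2)C(=O)c2ccc(C(=O)O)cc2)cc1`: > 100000 nM

The entry for compound 3 is a limit of the assay and not a number. Compound 3 stands only at the limit of > 100000 nM in this assay, at which 1 of the 3 values shown sits.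

Compound 4 `CSc1ccc(/C=C(/SCc2ccc(Cl)cc2)C(=O)c2ccc(Cl)cc2)cc1` differs from compound 3 in one place: chloro in place of carboxy on an aromatic carbon. Seen one bond further out, 4-carboxyphenyl becomes 4-chlorophenyl.

Going by the values given here, no measured step covers this exchange directly. Among the compounds with values here, the only measured step, a 50-fold lower number from compound 1 to compound 2 (1.70 log units; beyond the scatter), concerns another group, but it shows that one exchange can move the number a long way. Compound 1 and compound 2 already carry the chloro group at the place where compound 4 gains it, and both give real numbers in this assay. Compound 4 lacks the 3-methylthiophen-2-yl group of compound 1, so the expectation leans towards compound 2 at 1000 nM. A large step to a lower number is therefore expected, meaning stronger growth inhibition. The expected change is an at least 50-fold lower number from compound 3 to compound 4 (1.69 log units; beyond the scatter). For compound 4 the estimate is 2000 nM, with an expected range from 400 nM to 15000 nM.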

Compound 4, concentration for 50% growth inhibition: 25000 nM
Compound 4: the middle estimate sits 13-fold (1.10 log units) below what was measured; the whole stated range lies below it.
By their numbers in this assay, from the lowest: compound 2; then compounds 4 and 1 (each within the scatter of the next). At a limit, above all of these: compound 3.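

Compound 3 stands at a limit of this assay, not at a number: the limit of > 100000 nM in this assay, at which 1 of the 4 values shown sits.

With chloro in place of carboxy on the aromatic carbon, the series gains a real number at this position, and the change gives an at least 4.0-fold lower number from compound 3 to compound 4 (0.60 log units; beyond the scatter), so this exchange has a size only as a minimum. The chloro group alone does not bring the growth inhibition of compound 2, since methylsulfanyl in place of bromo on the other aromatic ring gives a 25-fold higher number from compound 2 to compound 4 (1.40 log units; beyond the scatter), while 4-(methylsulfanyl)phenyl in place of 3-methylthiophen-2-yl gives a 2.0-fold lower number from compound 1 to compound 4 (0.30 log units; within the scatter), a difference within the scatter, so compounds 1 and 4 count as alike here.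

As far as these compounds go, the carboxy-to-chloro exchange is seen only alongside the 4-(methylsulfanyl)phenyl group, so whether it would do the same alongside 4-bromophenyl stays open. Also open, from the compounds shown here alone, is what a methyl ester, a nitrile or an amine would do on the aromatic carbon that carries carboxy or chloro, and whether a methoxy group would behave like methylsulfanyl or like bromo on the other ring.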